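This account rests on a few compounds, and the source may have more. Where it says the series, first, only, none or still open, it means among the compounds named here.

Measured in a functional assay on HeLa cells (Homo sapiens) for cytotoxicity, read by ELISA, with a stated time of 4 days; on this read-out higher numbers stand for weaker inhibition and lower numbers for stronger inhibition:
Compound 1 `Cc1ccc(-c2cc(-c3ccoc3)cc(-c3ccc(Cl)s3)n2)o1`: 26500 nM
Compound 2 `Cc1cccc(-c2cc(-c3ccoc3)cc(-c3ccc(Cl)s3)n2)c1`: 23600 nM
Compound 3 `Clc1ccc(-c2cc(-c3ccoc3)cc(-c3ccccn3)n2)s1`: 21600 nM

The three numbers lie close together, and compound 3 cannot be separated from the other two. The comparisons show a 1.2-fold lower number from compound 1 to compound 3 (0.09 log units; within the scatter) and a 1.1-fold lower number from compound 2 to compound 3 (0.04 log units; within the scatter). The remaining comparison, a 1.1-fold lower number from compound 1 to compound 2 (0.05 log units; within the scatter), is just as small.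

Compound 4 `Clc1ccc(-c2cc(-c3ccoc3)cc(-c3cccnc3)n2)s1` has not yet been measured. It has pyridin-3-yl in place of pyridin-2-yl on an aromatic carbon of the shared core: pyridin-3-yl in place of pyridin-2-yl on an aromatic carbon. Going by the values given here, no measured step tests this exchange of pyridin-2-yl for pyridin-3-yl directly. The closest evidence comes from the two steps that end at compound 3, where 5-methylfuran-2-yl and 3-methylphenyl each give way to pyridin-2-yl at this same place. Both stay within the scatter, as a 1.2-fold lower number from compound 1 to compound 3 (0.09 log units; within the scatter) and a 1.1-fold lower number from compound 2 to compound 3 (0.04 log units; within the scatter) show. A step beyond the scatter is therefore not expected in this assay, and no direction is favoured. The estimate amounts to a 1.0-fold higher number from compound 3 to compound 4 (0.01 log units; within the scatter), an expected step no larger than the scatter. For compound 4 the expected value is 22000 nM, with an estimated range from 10000 nM to 45000 nM.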

Compound 4, half-maximal inhibitory concentration: 20000 nM
The estimate for compound 4 lay 1.1-fold (0.04 log units) above the measured number, within the range that was stated.
By their numbers in this assay, from the lowest: compounds 4, 3, 2 and 1 (each within the scatter of the next).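

Pyridin-3-yl and pyridin-2-yl have the same atoms joined differently, so this is the first comparison at this place, next to the ring nitrogen, that changes only how one ring is attached, and in this assay it gives (a 1.1-fold lower number from compound 3 to compound 4 (0.03 log units; within the scatter)). The two other steps ending at compound 4 also stay within the scatter, at (a 1.2-fold lower number from compound 2 to compound 4 (0.07 log units; within the scatter)) and (a 1.3-fold lower number from compound 1 to compound 4 (0.12 log units; within the scatter)), the latter being the largest step in the set, so 5-methylfuran-2-yl, 3-methylphenyl, pyridin-2-yl and pyridin-3-yl cannot be told apart at this place in this read-out. No supporting evidence is available that would account for this flat result.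

The compounds shown leave open whether a group of another kind at this place, such as a primary amine, a carboxylic acid or a longer alkyl chain, would move the number beyond the scatter. They also leave open whether this place would remain just as insensitive with something other than the furan-3-yl and 5-chlorothiophen-2-yl groups on the shared core, since every compound here carries both of them or differs only at the one place.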